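Swapping a Methoxy for a Methyl on Chromanone Side Chain

This account rests on a few compounds, and the source may have more. Where it says the series, first, only, none or still open, it means among the compounds named here.

Of the compounds shown here, three sharing one core have been measured in a functional assay on J774.A1 cells (Mus musculus) for inhibition, read by immunoassay, with a stated time of 12 h, tested at 30 uM; a lower number here means less inhibition, a higher number more inhibition at the concentration tested (going by the name of the read-out). Compound 1 `O=C1CC(c2ccccc2OCc2ccc(F)cc2)Oc2ccccc21` gives 42.1% in this assay, compound 2 `O=C1CC(c2ccccc2OCc2cccc(F)c2)Oc2ccccc21` gives 92.7%, and compound 3 `COCOc1ccccc1C1CC(=O)c2ccccc2O1` gives 33.3%. Compound 3 therefore stands lowest of the three, although its gap to compound 1 is within the scatter, while its gap to compound 2 is large.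

Compound 4 `CCOc1ccccc1C1CC(=O)c2ccccc2O1` has not yet been measured in this assay. It differs from compound 3 by one change: methyl in place of methoxy on a saturated chain carbon bound to an oxygen on an aromatic ring. The steps that touch the same saturated chain carbon bound to an oxygen on an aromatic ring are a number 8.8 percentage points lower from compound 1 to compound 3 (within the scatter) and a number 59.4 percentage points lower from compound 2 to compound 3 (beyond the scatter). For the measured compounds named here, the first shows that a group of the size in question can be exchanged with little effect, the second that a change there can also be very large. Going by the values given here, no measured step removes an oxygen from this chain, so the direction is open.

For compound 4 a step of about a number 3.7 percentage points higher from compound 3 to compound 4 (within the scatter) is expected, close to the scatter. Compound 4 is estimated at 37%, within 15% to 62%.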

Compound 4, a percentage reported as inhibition, at one concentration (the size of the read-out at that concentration, not a potency): 27.7%
Compound 4: the middle estimate sits 9.3 percentage points above what was measured; the measured number falls inside the stated range.
By their numbers in this assay, from the lowest: compounds 4, 3 and 1 (each within the scatter of the next, the first and the last beyond it); then compound 2.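

Methyl in place of methoxy on a saturated chain carbon bound to an oxygen on an aromatic ring is a step of a number 5.6 percentage points lower from compound 3 to compound 4 (within the scatter) in this assay so removing this oxygen from the small chain produces no change that can be told from scatter. For the compounds shown here, measured against the two fluorophenyl compounds, methyl gives a step of a number 14.4 percentage points lower from compound 1 to compound 4 (beyond the scatter) and a step of a number 65 percentage points lower from compound 2 to compound 4 (beyond the scatter) so compound 4 separates from compound 1 where compound 3 did not, while the far larger gap remains the one to compound 2. No measurement at hand explains any of these steps.

Going by these compounds, whether an amine or a carboxylic acid at the end of this chain would stay near compound 3 and compound 4 or move toward compound 2 remains open. The same holds for a longer chain such as propyl or butyl.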